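The source may hold more compounds than are shown below. What is called first, only, known or untested is meant among the compounds shown, and "the series" means these compounds.

Measured compounds in a physicochemical assay for solubility, read by spectrophotometry, measured as kinetic solubility, at pH 8, tested at 500 uM; on this read-out higher numbers stand for higher solubility and lower numbers for lower solubility:
compound 1, `CN1CCC(CNS(=O)(=O)c2ccccc2Nc2cc(-c3ccc4ccn(C)c4c3)c3nccnc3c2)C1`: 35 ug/mL
compound 2, `CN1CCC(NS(=O)(=O)c2ccccc2Nc2cc(-c3ccc4ccn(C)c4c3)c3nccnc3c2)C1`: 26 ug/mL
compound 3, `CN(C)C(=O)c1ccncc1Nc1cc(-c2ccc3ccn(C)c3c2)c2nccnc2c1`: 175 ug/mL

Compound 3 stands highest of the three numbers in this assay; its gap to compound 1 and to compound 2 lies beyond the scatter, while the values of compound 1 and compound 2 differ from each other only within it. For the measured compounds named here, the one step measured between compounds that differ in a single place is a 1.3-fold lower number from compound 1 to compound 2 (0.13 log units; within the scatter), a change on a sulfonamide nitrogen.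

Compound 4, `CN1CC(NC(=O)c2ccncc2Nc2cc(-c3ccc4ccn(C)c4c3)c3nccnc3c2)CCC1=O`, is not yet measured. It differs from compound 3 as follows: (1-methyl-6-oxopiperidin-3-yl)amino in place of dimethylamino on a carbonyl carbon. Going by the values given here, no measured step touches the carbonyl carbon of compound 3, so nothing measured bears directly on this change. Among the compounds with values here, the only step in hand, a 1.3-fold lower number from compound 1 to compound 2 (0.13 log units; within the scatter), exchanges one ring-bearing amine for another and stays within the scatter; by that analogy the step from compound 3 to compound 4 is expected to be small, with no clear direction. The value of compound 4 is expected near that of compound 3, as 150 ug/mL, ranging from 60 ug/mL to 350 ug/mL, an expected step of a 1.2-fold lower number from compound 3 to compound 4 (0.07 log units; within the scatter).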

Compound 4, solubility: 253 ug/mL
Compound 4: middle estimate off by 1.7-fold (0.23 log units), on the low side, within the range that was stated.
By their numbers in this assay, from the lowest: compounds 2 and 1 (each within the scatter of the next); then compounds 3 and 4 (each within the scatter of the next).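

In this assay, for the compounds shown here, the first measured step at this carbonyl carbon exchanges dimethylamino, which has no ring, for (1-methyl-6-oxopiperidin-3-yl)amino, which brings a six-membered non-aromatic ring and a hydrogen-bond donor (a 1.4-fold higher number from compound 3 to compound 4 (0.16 log units; within the scatter)). Compound 3 and compound 4 therefore stand level within the scatter, so this place accepts the larger substituent without a clear change in the read-out. No supporting measurement is available to explain this result.

This single step does not separate the contribution of the ring carbonyl from that of the amide hydrogen, since both enter together. Also open, as far as these compounds go, is how a morpholine ring or a longer dialkylamino chain on the same carbonyl carbon would read.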